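Pyrrole for piperidine amide on the sulfonamide side chain

The source may report more compounds than this note shows. Statements on the series, on what has been measured and on what is new or still open speak of the compounds shown alone.

Measured so far in an ADME assay on Caco-2 cells (Homo sapiens) for permeability, in the apical to basolateral direction; on this read-out lower numbers stand for lower permeability and higher numbers for higher permeability:
- compound 1, `Cn1cncc1CN1CC(N(CC2CCN(C(=O)OC(C)(C)C)CC2)S(=O)(=O)c2ccccn2)Cc2cc(C#N)ccc21`: compound 1 gives 15.5 10^-6 cm/s
- compound 2, `Cn1cncc1CN1CC(N(CCn2cccc2)S(=O)(=O)c2ccccn2)Cc2cc(C#N)ccc21`: compound 2 gives 12.4 10^-6 cm/s
- compound 3, `Cn1cncc1CN1CC(N(CC2CCN(C(=O)C(C)(C)C)CC2)S(=O)(=O)c2ccccn2)Cc2cc(C#N)ccc21`: compound 3 gives 0.5 10^-6 cm/s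

Compound 3 stands lowest of the three numbers in this assay; the gap to compound 2 and the gap to compound 1 are both beyond the scatter. The two measured steps that reach compound 3 are both large downward ones: a 31-fold lower number from compound 1 to compound 3 (1.49 log units; beyond the scatter) and a 25-fold lower number from compound 2 to compound 3 (1.39 log units; beyond the scatter).

Compound 4, `Cn1cncc1CN1CC(N(Cc2cccc(-n3cccc3)c2)S(=O)(=O)c2ccccn2)Cc2cc(C#N)ccc21`, is the next member and has not yet been measured in this assay. The change from compound 3 is 3-(1H-pyrrol-1-yl)phenyl in place of 1-((tert-butyl)carbonyl)piperidin-4-yl on a saturated chain carbon bound to a sulfonamide nitrogen. For the measured compounds named here, of the measured steps, the one from compound 2 to compound 3 bears most directly on it, since compound 2 also carries a pyrrole on the chain bound to the sulfonamide nitrogen; the step from compound 1 to compound 3 points the same way. Both steps were large, and reversing the piperidine amide is therefore expected to give a large step upward in this assay. Compound 4 is expected to come back roughly to the range of compound 1 and compound 2, with an estimated value of 14 10^-6 cm/s (range 6 10^-6 cm/s to 30 10^-6 cm/s), meaning an expected step of a 28-fold higher number from compound 3 to compound 4 (1.45 log units; beyond the scatter) from compound 3.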

Compound 4, apparent permeability: 2.3 10^-6 cm/s
The estimate for compound 4 lay 6.1-fold (0.78 log units) above the measured number, outside the stated range (below it).
By their numbers in this assay, from the lowest: compound 3; then compound 4; then compounds 2 and 1 (each within the scatter of the next).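

In this assay, a pyrrole on the side chain does not by itself restore the higher numbers: 3-(1H-pyrrol-1-yl)phenyl in place of 1-((tert-butyl)carbonyl)piperidin-4-yl gives only a 4.6-fold higher number from compound 3 to compound 4 (0.66 log units; beyond the scatter), whereas the same group in place of (1H-pyrrol-1-yl)methyl gives a 5.4-fold lower number from compound 2 to compound 4 (0.73 log units; beyond the scatter). On a saturated chain carbon bound to a sulfonamide nitrogen, the series therefore no longer splits simply into one low compound and a high pair, as compound 4 stands apart from both compound 3 and compound 2, with each gap beyond the scatter. No measurement in hand accounts for this order.

The compounds shown leave open whether the level of compound 4 is set by the phenyl ring, by the pyrrole on it, or by the two together, and a plain phenyl at this place would separate these readings. An amine or a carboxylic acid on that phenyl would show how far the number in this assay moves with a further change to this side chain.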